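A few compounds are considered here, and "the series" means these few. Any claim that something is new, unique, unknown or untested is made for them only; others in the source may bear on it.

The series shares a core that is visible in compound 2 `NCCCOc1ccc(CNc2nc3ccc(Oc4ccc(O)cc4)cc3s2)cc1`. For the measured compounds named here, in an assay on cells for inhibition of Voltage-dependent T-type calcium channel subunit alpha-1H (Homo sapiens), read by FLIPR and calcium flux, with stated times of 600 s and 300 s (on this read-out lower numbers stand for stronger inhibition and higher numbers for weaker inhibition), compound 2 gives 300000 nM, the second highest of the three numbers measured so far. Compound 3 `CN(Cc1ccc(OCCCNC(=N)N)cc1)c1nc2ccc(Oc3ccc(O)cc3)cc2s1` gives 332000 nM in this assay, which lies within the scatter of compound 2, so no order between these two can be read. Compound 1 `CN(Cc1ccc(OCCCN)cc1)c1nc2ccc(Oc3ccccc3)cc2s1` gives 95000 nM in this assay, a lower number than compound 2 by a gap beyond the scatter; compound 1 differs from compound 2 in more than one place, so the gap cannot be tied to a single change.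

Compound 4 `NCCCOc1ccc(CNc2nc3ccc(Oc4cccc(C(F)(F)F)c4)cc3s2)cc1` is not yet measured. It differs from compound 2 in one place: 3-(trifluoromethyl)phenyl in place of 4-hydroxyphenyl on an oxygen on an aromatic ring. Going by the values given here, no measured pair shows this change on its own, so the size of the step is not known. Among the compounds with values here, compound 1, the one measured compound without the 4-hydroxyphenyl group, gives 95000 nM, the lowest number of the three, which weakly supports a lower number for compound 4. The expected step from compound 2 to compound 4 in this assay is a 2.7-fold lower number from compound 2 to compound 4 (0.44 log units; beyond the scatter), a move towards a lower number that may not clear the scatter. Compound 4 is therefore expected to give 110000 nM in this assay, with a range from 30000 nM to 350000 nM.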

Compound 4, half-maximal inhibitory concentration: 171000 nM
Estimate against measurement, compound 4: 1.6-fold (0.19 log units) below; the measured number falls inside the stated range.
By their numbers in this assay, from the lowest: compounds 1, 4, 2 and 3 (each within the scatter of the next, the first and the last beyond it).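

In this assay, for the compounds shown here, the first single-place step, a 1.8-fold lower number from compound 2 to compound 4 (0.24 log units; within the scatter), stays within the scatter, so no order can be read between these two compounds. At this place, on an oxygen on an aromatic ring, 3-(trifluoromethyl)phenyl, which has no hydrogen-bond donor or acceptor, stands in for 4-hydroxyphenyl, which has both, and the number does not move beyond the scatter, so the hydroxy group is not shown to be needed for the values seen here. Nothing on hand bears on why this step is as small as it is.

The step changes both the group on the ring and where it sits, so the two changes cannot be separated, and 3-hydroxyphenyl or 4-(trifluoromethyl)phenyl on the same oxygen would be needed to tell them apart. Also open, from the compounds shown here alone, is whether a ring at this place carrying a carboxylic acid, an amine or a nitrile would give a step beyond the scatter, in either direction, on the background of compound 2.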